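A Smaller Amide on a Shared Core

The source may hold more compounds than are shown below. What is called first, only, known or untested is meant among the compounds shown, and "the series" means these compounds.

compound 1, `CC(C)n1nc(-c2ccnc3[nH]c(C4CCN(CC(=O)N(C)C)CC4)cc23)ccc1=O`: 72 mL/min/kg
compound 2, `CC(C)n1cc(-c2ccnc3[nH]c(C4CCN(CC(=O)N5CCCC5)CC4)cc23)ccc1=O`: 91 mL/min/kg
compound 3, `COc1cc(C(=O)N2CCCC2)ccc1-c1ccnc2[nH]c(C3CCNCC3)cc12`: 17 mL/min/kg

These three compounds were run in an ADME assay (Rattus norvegicus, strain Han-wistar) for pharmacokinetics, at a dose of 1.5 umol/kg by the intravenous route; a higher number here means faster removal of the compound, a lower number slower removal. Compound 2 shows the highest of the three numbers, though compound 1 stands nearest and its value lies within the usual scatter of that of compound 2, so no order can be read between the two. For the measured compounds named here, compound 3 stands furthest from compound 2, with a gap beyond the scatter; it differs from compound 2 in several places at once, so no single step is drawn between them.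

Compound 4, `CNC(=O)CN1CCC(c2cc3c(-c4ccc(=O)n(C(C)C)c4)ccnc3[nH]2)CC1`, has not yet been measured. It differs from compound 2 in one place: methylamino in place of pyrrolidin-1-yl on a carbonyl carbon. Going by the values given here, no step between measured compounds matches this change, so the expectation rests on compounds 1 and 2 alone, whose values sit close together at the high end. The expected step of a 1.4-fold lower number from compound 2 to compound 4 (0.15 log units; within the scatter) is small and downward, most likely within the scatter. The estimate for compound 4 is 65 mL/min/kg, with a range from 32 mL/min/kg to 120 mL/min/kg.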

Compound 4, clearance: 89 mL/min/kg
Estimate against measurement, compound 4: 1.4-fold (0.14 log units) below; the measured number falls inside the stated range.
By their numbers in this assay, from the lowest: compound 3; then compounds 1, 4 and 2 (each within the scatter of the next).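

In this assay, methylamino in place of pyrrolidin-1-yl on a carbonyl carbon gives a 1.0-fold lower number from compound 2 to compound 4 (0.01 log units; within the scatter), which lies within the scatter, so no difference can be read from this exchange. For the compounds shown here, this is the first step that isolates a single change at this position, since compounds 1 and 2 differ in more than one place, and it shows that a ring-free group bearing the amide hydrogen can take the place of the pyrrolidin-1-yl ring without a readable difference in this pair. Nothing in the data given accounts for this result.

Still open, from the compounds shown here alone, is whether a group of another kind at this position, such as a carboxylic acid in place of the amide or an amine carried on a longer chain, would give a step beyond the scatter. Also open, going by these compounds, is whether the same exchange would read alike in compound 3, where pyrrolidin-1-yl also sits on a carbonyl carbon but the number printed is 17 mL/min/kg.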